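Adding a Cyclohexyl to the Amide of Compound 3

The source may hold more compounds than are shown below. What is called first, only, known or untested is meant among the compounds shown, and "the series" means these compounds.

Of the compounds shown here, three sharing one core have been measured in an assay on CHO-K1 cells for displacement of a labelled ligand from prostaglandin E2 receptor EP1 subtype (Homo sapiens); a higher number here means a weaker inhibitor, a lower number a stronger inhibitor. Compound 1 `Cc1cc(C(=O)NC(C)C)nn1Cc1cc(Cl)ccc1OCc1ccccc1` gives 126 nM. Compound 2 `Cc1cc(C(=O)NCc2ccccc2)nn1Cc1cc(Cl)ccc1OCc1ccccc1` gives 39.8 nM, and compound 3 `CC(=O)Nc1cc(C)n(Cc2cc(Cl)ccc2OCc2ccccc2)n1` gives 316 nM, the highest of the three numbers. The steps of a 3.2-fold lower number from compound 1 to compound 2 (0.50 log units; beyond the scatter) and a 7.9-fold higher number from compound 2 to compound 3 (0.90 log units; beyond the scatter) and a 2.5-fold higher number from compound 1 to compound 3 (0.40 log units; beyond the scatter) all lie beyond the scatter, so compound 3 is the weakest inhibitor of the set.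

Compound 4 `Cc1cc(NC(=O)CC2CCCCC2)nn1Cc1cc(Cl)ccc1OCc1ccccc1` differs from compound 3 by cyclohexyl in place of hydrogen on a saturated chain carbon bound to a carbonyl carbon. Among the measured compounds shown here, no measured step makes exactly this change, but the step of a 3.2-fold lower number from compound 1 to compound 2 (0.50 log units; beyond the scatter) shows that a larger group on the amide side of the core went with a lower number, and the acetamido compound 3 sits highest. On that basis, a modest lowering is expected in this assay, so that compound 4 is estimated at 130 nM, with a plausible range from 50 nM to 400 nM; this expected step is a 2.4-fold lower number from compound 3 to compound 4 (0.39 log units; beyond the scatter).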

Compound 4, half-maximal inhibitory concentration: 6.31 nM
Compound 4: the middle estimate sits 21-fold (1.31 log units) above what was measured; measured number below the stated range.
By their numbers in this assay, from the lowest: compound 4; then compound 2; then compound 1; then compound 3.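

In this assay the cyclohexyl on the saturated chain carbon bound to the carbonyl carbon gives a 50-fold lower number from compound 3 to compound 4 (1.70 log units; beyond the scatter) and turns the weakest inhibitor of the earlier set into the strongest of the four. The earlier compounds shown here gave no sign that this acetamido side of the shared core could reach so low, yet ((cyclohexylmethyl)carbonyl)amino outdoes benzylcarbamoyl with a 6.3-fold lower number from compound 2 to compound 4 (0.80 log units; beyond the scatter) and isopropylcarbamoyl with a 20-fold lower number from compound 1 to compound 4 (1.30 log units; beyond the scatter) on that same aromatic carbon. Among the compounds shown here, no outside evidence bears on why this one change lowers the number so far.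

The compounds shown leave open whether the ring itself or simply the added carbon chain carries the change, which a straight hexyl chain or a phenyl ring in place of cyclohexyl would help to separate. They also leave open how an amine or a carboxylic acid on the cyclohexyl would read in this assay.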